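Amino in place of 1-hydroxyethyl on the phenoxy ring

This account rests on a few compounds, and the source may have more. Where it says the series, first, only, none or still open, it means among the compounds named here.

Compound 1 `CC(Nc1ccccc1Oc1cccc(F)c1)=C1C(=O)CC(c2ccccc2)CC1=O` gives 330 nM in a functional assay on L1210 cells (Mus musculus) for antiproliferative activity, read by cell counting, with a stated time of 96 h; a lower number here means a stronger inhibitor, a higher number a weaker inhibitor. For the measured compounds named here, compound 2 `CC(Nc1ccccc1Oc1ccc(C(C)O)cc1)=C1C(=O)CC(c2ccccc2)CC1=O` gives 58 nM in this assay, the lowest of the two numbers so far. Going by the values given here, the one measured step, a 5.7-fold lower number from compound 1 to compound 2 (0.76 log units; beyond the scatter), sits on the same aromatic ring that is changed next. Compound 3 `CC(Nc1ccccc1Oc1ccc(N)cc1)=C1C(=O)CC(c2ccccc2)CC1=O` differs from compound 2 by amino in place of 1-hydroxyethyl on an aromatic carbon. Among the compounds with values here, that single step is the only guide; it shows that a change on this ring moved the number beyond the scatter, but no measured pair tests an amino group here. A step of about a 1.4-fold higher number from compound 2 to compound 3 (0.14 log units; within the scatter) is therefore expected, within the scatter. Compound 3 is estimated at 80 nM, with a range of 30 nM to 250 nM.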

Compound 3, half-maximal inhibitory concentration: 40 nM
Beside the measured number, compound 3's estimate is 2.0-fold (0.30 log units) above it, within the range that was stated.
By their numbers in this assay, from the lowest: compounds 3 and 2 (each within the scatter of the next); then compound 1.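

Replacing 1-hydroxyethyl with amino on this aromatic carbon gives a 1.5-fold lower number from compound 2 to compound 3 (0.16 log units; within the scatter) in this assay, so the two groups cannot be told apart here. The separation from the 3-fluorophenyl compound persists with amino, at an 8.3-fold lower number from compound 1 to compound 3 (0.92 log units; beyond the scatter). No evidence on the reason for either step is available.

Open, from the compounds shown here alone, is how a carboxylic acid or a dimethylamino group would read on the same aromatic carbon. Also open, going by these compounds, is whether a longer chain ending in an amine would stay level with compound 3.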